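Ethyl for fluoro on the aryl sulfonamide: lipophilicity expectation

The compounds below may be only part of what the source reports. "The series", "measured", "known", "first", "only" and "open" are said of these compounds alone.

Measured compounds:
Compound 1 `CCc1ccc(N(CC(C)C)S(=O)(=O)c2ccc3c(c2)C(=O)CC(c2c(C)noc2C)O3)cc1` gives 4.42 in a physicochemical assay for lipophilicity, at pH 7.4; on this read-out higher numbers stand for higher lipophilicity and lower numbers for lower lipophilicity.
Compound 2 `CCc1ccc(N(CC(C)C)S(=O)(=O)c2ccc3c(c2)C(=O)CC(C2(C)CCOCC2)O3)cc1` gives 4.71 in this assay.
Compound 3 `CC(C)CN(c1ccc(F)cc1)S(=O)(=O)c1ccc2c(c1)C(=O)CC(C1CCOCC1)O2` gives 3.48 in this assay.

Compound 3 stands lowest of the three in this assay; compound 1 lies above it by a margin beyond the scatter, and compound 2 lies further above still. Among the measured compounds shown here, the one measured step, a number 0.29 log units higher from compound 1 to compound 2 (within the scatter), concerns a different place on the core and so does not bear directly on the change in question. Compound 4 `CCc1ccc(N(CC(C)C)S(=O)(=O)c2ccc3c(c2)C(=O)CC(C2CCOCC2)O3)cc1` differs from compound 3 in one place: ethyl in place of fluoro on an aromatic carbon. For the measured compounds named here, no measured pair isolates this change; compound 3 differs from compound 1 and from compound 2 in two places at once, so their values show only that the ethyl-bearing compounds sit well above compound 3. Starting from compound 3, a step upward in this assay of a number 0.82 log units higher from compound 3 to compound 4 (beyond the scatter) is expected for compound 4, reaching roughly the range of compound 1 and compound 2. Compound 4 is estimated at 4.3, between 3.9 and 4.7.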

Compound 4, distribution coefficient: 4.21
Estimate against measurement, compound 4: 0.09 log units above, and the stated range covers the measured number.
By their numbers in this assay, from the lowest: compound 3; then compounds 4, 1 and 2 (each within the scatter of the next, the first and the last beyond it).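

The pair formed by compound 3 and compound 4 isolates the change at this aromatic carbon: in this assay, 4-ethylphenyl in place of 4-fluorophenyl gives a number 0.73 log units higher from compound 3 to compound 4 (beyond the scatter), a modest step. Compound 4 also adds to the comparisons at the saturated ring carbon, where hydrogen in place of methyl gives a number 0.50 log units lower from compound 2 to compound 4 (beyond the scatter), and oxan-4-yl in place of 3,5-dimethyl-1,2-oxazol-4-yl gives a number 0.21 log units lower from compound 1 to compound 4 (within the scatter). Nothing among the results shown offers a measured explanation for these steps.

As far as these compounds go, the change from fluoro to ethyl rests on this single pair, so whether it holds with 4-methyloxan-4-yl or 3,5-dimethyl-1,2-oxazol-4-yl on the saturated ring carbon remains open. From the compounds shown here alone, how this assay would respond to an amine, a carboxylic acid or a longer chain on the aromatic carbon also remains open.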